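The source may report more compounds than this note shows. Statements on the series, on what has been measured and on what is new or still open speak of the compounds shown alone.

Compound 1 `O=C(COc1ccc(C(=O)/C=C/c2cccc(Cl)c2)cc1)N[C@H]1CCOC1=O`: 3700 nM
Compound 2 `O=C(CNc1ccc(Br)cc1)N[C@H]1CCOC1=O`: > 64000 nM

In a functional assay on DU-145 cells (Homo sapiens) for antiproliferative activity, read by MTT assay, with a stated time of 72 h (a lower number here means a stronger inhibitor, a higher number a weaker inhibitor), compound 1 gives 3700 nM, the only real number shown here. Compound 2 gives only a limit of the assay, not a number, namely (the limit of > 64000 nM in this assay, at which 1 of the 2 values shown sits). Compound 3 `O=C(COc1ccc(C(=O)/C=C/c2cccc([N+](=O)[O-])c2)cc1)N[C@H]1CCOC1=O` has not yet been measured. It differs from compound 1 by nitro in place of chloro on an aromatic carbon. For the measured compounds named here, no measured step links these compounds, so the size of this change is uncertain; in this assay a step within the usual scatter is expected, with no clear direction. Compound 3 is estimated at 4500 nM, between 1500 nM and 14000 nM. The expected step is a 1.2-fold higher number from compound 1 to compound 3 (0.09 log units; within the scatter).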

Compound 3, half-maximal inhibitory concentration: 41800 nM
Beside the measured number, compound 3's estimate is 9.3-fold (0.97 log units) below it, and the stated range ends below it.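

In this assay, replacing chloro with nitro on the aromatic ring gives an 11-fold higher number from compound 1 to compound 3 (1.05 log units; beyond the scatter), so compound 3 is clearly the weaker inhibitor. This place on the ring is therefore not indifferent to what sits there, which compound 1 alone could not show. Nothing shown here explains why the change costs so much activity.

For the compounds shown here, only two groups at this place can be compared, so it remains open how an amine, a methyl group or a plain hydrogen there would behave. Going by these compounds, whether the same swap has a similar effect in other cell lines also remains open.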